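From compound 3 to compound 4: methyl for methylamino

The source may hold more compounds than are shown below. What is called first, only, known or untested is meant among the compounds shown, and "the series" means these compounds.

Compound 1 `Cc1ncnc2c1c(-c1ccoc1)cn2[C@@H]1O[C@H](CO)[C@@H](O)[C@H]1O`: 89200 nM
Compound 2 `Cc1ncnc2c1c(-c1cccs1)cn2[C@@H]1O[C@H](CO)[C@@H](O)[C@H]1O`: > 100000 nM
Compound 3 `CNc1ncnc2c1c(I)cn2[C@@H]1O[C@H](CO)[C@@H](O)[C@H]1O`: > 100000 nM

All three were tested in an ADME assay on BJ cells (Homo sapiens), read by MTT assay, with a stated time of 72 h; on this read-out lower numbers stand for stronger inhibition and higher numbers for weaker inhibition. The entries for compound 2 and compound 3 are limits of the assay and not numbers. Compound 3 therefore stands at the limit of > 100000 nM in this assay, at which 2 of the 3 values shown sit.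

Compound 4 `Cc1ncnc2c1c(I)cn2[C@@H]1O[C@H](CO)[C@@H](O)[C@H]1O` differs from compound 3 in one place: methyl in place of methylamino on an aromatic carbon. Methyl takes the place of methylamino on an aromatic carbon.

Within the data shown here, no measured step makes this change. Among the measured compounds shown here, the only measured step is an at least 1.1-fold higher number from compound 1 to compound 2 (0.04 log units; that floor lies within the scatter), and it belongs to a different swap, thiophen-2-yl in place of furan-3-yl. It offers no measure of the new change, so the closest guide is a compound that shares the methyl. Compound 1 carries methyl in that place and gives 89200 nM.

Little or no change beyond the scatter is therefore expected, and any change should be towards a lower number. The expected step is an at least 1.2-fold lower number from compound 3 to compound 4 (0.09 log units; that floor lies within the scatter). For compound 4 the estimate is 80000 nM, with an expected range from 20000 nM to 100000 nM.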

Compound 4, half-maximal inhibitory concentration: > 100000 nM
Compound 4 gave a limit, no number; the forecaster's own chance of this, stated with the estimate: 55%; middle value at least 1.2-fold (0.09 log units) from the limit.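

Compound 4, with methyl in place of methylamino, also ends at a limit and not at a number in this assay: the limit of > 100000 nM in this assay, at which 3 of the 4 values shown sit. The steps to compound 4 from compound 3 and from compound 2 cannot be read, as both ends of each are limits. Among these compounds, the one readable step, an at least 1.1-fold higher number from compound 1 to compound 4 (0.04 log units; that floor lies within the scatter), puts iodo in place of furan-3-yl, and its floor alone does not show that the two groups differ beyond the scatter.

As far as these compounds go, how far compound 2, compound 3 and compound 4 lie past the limit remains open, so neither methyl nor methylamino can yet be ranked at this position with iodo present. Also open, from the compounds shown here alone, is whether a plain amine or a longer chain such as ethyl in this place would give a number within the range of the assay.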